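Dropping the Acetyl: From Compound 2 to Compound 3

The compounds below may be only part of what the source reports. "The series", "measured", "known", "first", "only" and "open" are said of these compounds alone.

Compound 1 `CC(=O)O[C@@H]1CC(C)=C(CCC2=CC(=O)OC2)[C@@]2(C)CCCC(C)(C)[C@H]12`: < 5 ug/mL
Compound 2 `CC(=O)O[C@@H]1C[C@@H](C)[C@](O)(CCC2=CC(=O)OC2)[C@@]2(C)CCCC(C)(C)[C@H]12`: < 5 ug/mL

In a functional assay on A549 cells (Homo sapiens) for cytotoxicity, read by MTT assay, with a stated time of 72 h (on this read-out higher numbers stand for weaker inhibition and lower numbers for stronger inhibition), compound 1 reaches only a limit, < 5 ug/mL, not a number. Compound 2 likewise stops at a limit, < 5 ug/mL, in this assay. Within the data shown here, compound 2 therefore stands at the limit of < 5 ug/mL in this assay, at which 2 of the 2 values shown sit, and no measured step separates it from compound 1. Compound 3 `C[C@@H]1C[C@@H](O)[C@H]2C(C)(C)CCC[C@]2(C)[C@@]1(O)CCC1=CC(=O)OC1` is not yet measured; it differs from compound 2 in one place: hydrogen in place of acetyl on an oxygen on a saturated carbon. Among the measured compounds shown here, with no measured step of this kind to lean on, the expected shift a step that the limit leaves unreadable from compound 2 to compound 3 is none beyond the scatter. Compound 3 is estimated at 4 ug/mL, between 1.5 ug/mL and 12 ug/mL, with a fair chance that only a limit is reported again.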

Compound 3, half-maximal inhibitory concentration: < 5 ug/mL
Compound 3 gave a limit, no number; the forecaster's own chance of this, stated with the estimate: 40%; the middle value is on the limit's open side.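

In this assay, compound 2 and compound 3 both stop at a limit, so no step between them can be read: the limit of < 5 ug/mL in this assay, at which 3 of the 3 values shown sit.

The compounds shown leave open how strong each one actually is, and whether going from acetoxy to hydroxy changes that at all.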